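The source may hold more compounds than are shown below. What is called first, only, known or untested is meant among the compounds shown, and "the series" means these compounds.

Measured so far in a physicochemical assay for lipophilicity, at pH 7.4; on this read-out higher numbers stand for higher lipophilicity and lower numbers for lower lipophilicity:
- compound 1 `CNC(=O)c1cc(C)n(Cc2cc(Cl)ccc2OCc2ccccc2)n1`: > 3.7 (a limit, not a number)
- compound 2 `Cc1cc(C(=O)Nc2cccc(F)c2)nn1Cc1cc(Cl)ccc1OCc1ccccc1`: 2.8
- compound 3 `Cc1cc(NC(=O)C(C)C)nn1Cc1cc(Cl)ccc1OCc1ccccc1`: > 3.7 (a limit, not a number)

In this assay compound 3 gives > 3.7, which is a limit and not a number. The set as a whole holds (the limit of > 3.7 in this assay, at which 2 of the 3 values shown sit).

The next compound is compound 4 `Cc1cc(NC(=O)C2CCOC2)nn1Cc1cc(Cl)ccc1OCc1ccccc1`, with oxolan-3-yl in place of isopropyl on a carbonyl carbon.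

Among the measured compounds shown here, no measured step makes this exact change, so the bearing of the steps in hand is indirect. Two of them, both at other places, lie beyond the scatter: a number at least 0.90 log units lower from compound 1 to compound 2 (beyond the scatter) and a number at least 0.90 log units higher from compound 2 to compound 3 (beyond the scatter). The third cannot be sized: a step that the two limits leave unreadable from compound 1 to compound 3. For the measured compounds named here, these steps show only that single changes in this small set can move the read-out well past the scatter.

For the swap itself, a modest downward step is expected. The estimated step is a number at least 0.40 log units lower from compound 3 to compound 4 (beyond the scatter). A reading at the limit remains possible.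

For compound 4 the expected value is 3.3, with an estimated range of 2.8 to 3.8.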

Compound 4, distribution coefficient: > 3.7
Compound 4 gave a limit, no number; the forecaster's own chance of this, stated with the estimate: 25%; middle value at least 0.40 log units away from the limit.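

In this assay compound 4 gives > 3.7, which is a limit and not a number. Among the compounds shown here, at this place, on a carbonyl carbon whose other neighbour is an amide-type nitrogen, exchanging isopropyl for oxolan-3-yl therefore still gives no number, even with the ring and the hydrogen-bond acceptor that enter, and the only readable comparison is with the one compound in the set that has a number, a number at least 0.90 log units higher from compound 2 to compound 4 (beyond the scatter). The steps from compound 1 and from compound 3 to compound 4 cannot be read, so the size of this swap stays unknown and the set remains crowded at the top of the measurable range: the limit of > 3.7 in this assay, at which 3 of the 4 values shown sit.

Still open, going by these compounds, is whether oxolan-3-yl in place of isopropyl moves the read-out at all, and by how much, as both compounds of that pair are given only as limits. Also open, on these data alone, is whether an amine or a carboxylic acid in place of isopropyl on this carbonyl carbon would give a number in this assay, which would allow the amide series to be sized step by step.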